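The compounds below may be only part of what the source reports. "The series", "measured", "known", "first", "only" and "open" are said of these compounds alone.

Measured in an ADME assay on liver (Mus musculus) for metabolic stability, read by LC-MS, using microsomes and NADPH; a lower number here means that less of the compound is left, a higher number that more of the compound is left:
- Compound 1 `Cc1cc(CN(CC2CC2)C(CC(=O)O)c2ccc(Cl)cc2)ccc1OCCN1C(=O)CCC1=O`: 83%
- Compound 2 `Cc1cc(CN(CC2CC2)[C@@H](CC(=O)O)c2ccc(Cl)cc2)ccc1OCCN1C(=O)CCC1=O`: 87%

Among the compounds with values here, compound 1 stands at 83%, and the only measured comparison available for it shows little difference: a number 4 percentage points higher from compound 1 to compound 2 (within the scatter). That step concerns (the fact that one of compounds 1 and 2 is drawn with a defined configuration and the other without, at the place where they differ), and the cyclopropyl group stays in place on both sides of it.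

Compound 3 `Cc1cc(CN(CC2CCCCC2)C(CC(=O)O)c2ccc(Cl)cc2)ccc1OCCN1C(=O)CCC1=O` keeps the shared core of compound 1 and alters that group instead: cyclohexyl in place of cyclopropyl on a saturated chain carbon bound to an amine nitrogen. The change puts cyclohexyl in place of cyclopropyl on a saturated chain carbon bound to an amine nitrogen. Within the data shown here, no measured step covers a change of this kind, so the small stereo step gives no guide to its size and the expectation remains loose.

The estimate starts from compound 1 at 83%, a number that leaves ample room for a fall, and the entering ring is the larger one. A moderate downward move is therefore expected, although a result within the scatter would not be surprising: a number 13 percentage points lower from compound 1 to compound 3 (beyond the scatter). For compound 3, the expected value is 70%, with an estimated range from 50% to 88%.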

Compound 3, percent of the compound remaining: 57%
The estimate for compound 3 lay 13 percentage points above the measured number; the range from low to high includes it.
By their numbers in this assay, from the lowest: compound 3; then compounds 1 and 2 (each within the scatter of the next).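

In this assay, cyclohexyl in place of cyclopropyl on a saturated chain carbon bound to an amine nitrogen gives a number 26 percentage points lower from compound 1 to compound 3 (beyond the scatter), and this is the only step shown that lies beyond the scatter. The earlier pair differed only in how a stereocentre was drawn and stayed within the scatter, so this position is now seen to respond to a change of the group itself, with the six-membered ring leaving less compound than the three-membered ring. This rests on a single pair, and nothing measured here bears on why the number falls.

The compounds shown leave open whether the fall tracks ring size step by step, as cyclobutyl or cyclopentyl at this place would show, or whether an open chain such as isobutyl or an oxygen-containing ring such as tetrahydropyranyl would read differently. They also leave open whether a form of compound 3 with a defined stereocentre would stay within the scatter of compound 3, as compound 2 does of compound 1.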